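The source may report more compounds than this note shows. Statements on the series, on what has been measured and on what is new or still open speak of the compounds shown alone.

In a functional assay on Caco-2 cells (Homo sapiens) for antiproliferative activity, read by MTT assay, with a stated time of 48 h (on this read-out higher numbers stand for weaker inhibition and lower numbers for stronger inhibition), compound 1 `CCn1c(C(=O)Nc2ccc(OC(F)(F)F)cc2)ccc1C(CC)(CC)c1ccc(OCCC(O)(CC)CC)c(C)c1` gives > 50000 nM, which is a limit of the assay and not a number. Going by the values given here, compound 2 `CCOC(=O)C(CC(=O)OC)NC(=O)c1ccc(C(CC)(CC)c2ccc(OCCC(O)(CC)CC)c(C)c2)n1CC` gives 3020 nM, the only actual number so far. Among the compounds with values here, the single measured step, an at least 16-fold lower number from compound 1 to compound 2 (1.21 log units; beyond the scatter), is large, but it replaces a group containing a six-membered aromatic ring, so it bears only loosely on the next change. Compound 3 `CCn1c(C(=O)NC(CC(=O)O)C(=O)OC)ccc1C(CC)(CC)c1ccc(OCCC(O)(CC)CC)c(C)c1` differs from compound 2 on the amide-type nitrogen: a group of 9 heavy atoms (5 carbon, 4 oxygen; no ring) in place of a group of 11 heavy atoms (7 carbon, 4 oxygen; no ring), on an amide-type nitrogen. A moderate move toward weaker inhibition is expected, a 2.6-fold higher number from compound 2 to compound 3 (0.42 log units; beyond the scatter). For compound 3 the estimate is 8000 nM, with an expected range from 2000 nM to 35000 nM.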

Compound 3, half-maximal inhibitory concentration: 25200 nM
Estimate against measurement, compound 3: 3.2-fold (0.50 log units) below, within the range that was stated.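

In this assay, two groups without a ring on the amide-type nitrogen still differ clearly, with an 8.3-fold higher number from compound 2 to compound 3 (0.92 log units; beyond the scatter), so this position responds even when no aromatic ring is involved. Against the group with the six-membered aromatic ring, the change gives an at least 1.9-fold lower number from compound 1 to compound 3 (0.29 log units; that floor lies within the scatter), which fixes no order between these two compounds. Compound 1 holds a limit of the assay and not a number: the limit of > 50000 nM in this assay, at which 1 of the 3 values shown sits.

From the compounds shown here alone, whether an amine or a longer ester chain in this group would bring the number below that of compound 2 remains open.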